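A few compounds are considered here, and "the series" means these few. Any claim that something is new, unique, unknown or untested is made for them only; others in the source may bear on it.

Of the compounds shown here, three built on the same core have been measured in an in vitro assay on CHOK cells for displacement of a labelled ligand from growth hormone secretagogue receptor type 1 (Homo sapiens); a higher number here means a weaker inhibitor, a lower number a stronger inhibitor. Compound 1 `CC(=O)c1ccc(CNc2ccc(-c3c(N)nc(N)nc3COCc3ccccc3)cc2)cc1` gives 1.2 nM, compound 2 `N#Cc1ccc(CNc2ccc(-c3c(N)nc(N)nc3COCc3ccccc3)cc2)cc1` gives 2.8 nM, and compound 3 `Nc1nc(N)c(-c2ccc(NCc3csc(Cl)c3)cc2)c(COCc2ccccc2)n1` gives 6.3 nM. Compound 3 thus stands at the highest number of the three, which in this assay means the weakest inhibitor of the set.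

Compound 4 `COc1ccc(CNc2ccc(-c3c(N)nc(N)nc3COCc3ccccc3)cc2)cc1` is not yet measured. It differs from compound 3 in one place: 4-methoxyphenyl in place of 5-chlorothiophen-3-yl on a saturated chain carbon bound to a nitrogen on an aromatic ring. Among the compounds with values here, two measured steps bear directly on this change, since both replace a substituted phenyl with the chlorothiophenyl ring at the same place. The step of a 5.3-fold higher number from compound 1 to compound 3 (0.72 log units; beyond the scatter) and the step of a 2.3-fold higher number from compound 2 to compound 3 (0.35 log units; beyond the scatter) both moved the number upward; read in reverse, putting a six-membered carbon ring back in this position has so far brought the number down, by a modest amount each time. The methoxy-bearing ring of compound 4 is a third variation of the same kind, so a modest downward step is expected rather than none.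

Compound 4 is therefore estimated to give about 2.5 nM in this assay, with a range from 1 nM to 6.5 nM, which would amount to the expected step of a 2.5-fold lower number from compound 3 to compound 4 (0.40 log units; beyond the scatter).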

Compound 4, half-maximal inhibitory concentration: 7.7 nM
Compound 4: middle estimate off by 3.1-fold (0.49 log units), on the low side; the whole stated range lies below it.
By their numbers in this assay, from the lowest: compound 1; then compound 2; then compounds 3 and 4 (each within the scatter of the next).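

In this assay, within the data shown here, the earlier steps seemed to say that a six-membered carbon ring at this position brings the number down, yet a 1.2-fold higher number from compound 3 to compound 4 (0.09 log units; within the scatter) shows no such gain for 4-methoxyphenyl, which cannot be told apart from 5-chlorothiophen-3-yl here. Among these compounds, the ring alone therefore does not decide the result, and the group it carries does: with the same benzyl link to the amino nitrogen and only that group changed, methoxy gives a 2.8-fold higher number from compound 2 to compound 4 (0.44 log units; beyond the scatter) against cyano and a 6.4-fold higher number from compound 1 to compound 4 (0.81 log units; beyond the scatter) against acetyl. So the low numbers of the earlier compounds belong to the acetyl and cyano rings and do not extend to every substituted phenyl ring, and nothing available here explains why these groups differ.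

With only acetyl, cyano and methoxy shown on this ring, it remains open how a carboxylic acid, an amine or a longer chain in their place would read in this assay. Also open is what the chlorine contributes to the thiophene ring of compound 3, since a thiophene ring carrying a methyl group or no group at all is not among the compounds shown.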